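Propylsulfanyl for benzyloxy on the shared core

A few compounds are considered here, and "the series" means these few. Any claim that something is new, unique, unknown or untested is made for them only; others in the source may bear on it.

In an ADME assay on CCRF-HSB-2 cells (Homo sapiens) for cytotoxicity, with a stated time of 7 days (on this read-out lower numbers stand for higher toxicity in this test and higher numbers for lower toxicity in this test), compound 3 (`Nc1nc(OCc2ccccc2)c2ncn(/C=C3/CC3(CO)CO)c2n1`) gives > 20000 nM as a limit, not a number. Compound 1 (`C=CCOc1nc(N)nc2c1ncn2/C=C1/CC1(CO)CO`) gives > 20000 nM as a limit too. Compound 2 (`CCOc1nc(N)nc2c1ncn2/C=C1/CC1(CO)CO`) gives > 20000 nM as a limit as well. Within the data shown here, the series so far therefore stands at the limit of > 20000 nM in this assay, at which 3 of the 3 values shown sit, with no number to rank.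

propylsulfanyl in place of benzyloxy on an aromatic carbon is the change that leads to compound 4 (`CCCSc1nc(N)nc2c1ncn2/C=C1/CC1(CO)CO`), propylsulfanyl in place of benzyloxy on an aromatic carbon. Among the measured compounds shown here, three measured steps bear on it: a step that the two limits leave unreadable from compound 1 to compound 2 and a step that the two limits leave unreadable from compound 1 to compound 3 and a step that the two limits leave unreadable from compound 2 to compound 3 all swap the chain on the oxygen, and none has a readable size. For the measured compounds named here, no measured compound carries sulfur at this carbon, so this part of the change is untested.

No step beyond the scatter is expected, and any departure would be expected toward higher toxicity in this test. The estimated step is a number no higher from compound 3 to compound 4 (the limit leaves the size open) in this assay and it may well stay unreadable. For compound 4 the estimated value is 20000 nM with an expected range of 8000 nM to 25000 nM and a further limit is the likeliest report.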

Compound 4, half-maximal cytotoxic concentration: 98000 nM
Compound 4: the middle estimate sits 4.9-fold (0.69 log units) below what was measured; measured number above the stated range.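

In this assay, among these compounds, no step to compound 4 can be read from compound 1, compound 2 or compound 3, as each of those three gives only a limit. The compounds shown leave open whether sulfur or oxygen at this aromatic carbon matters, and how large any of these swaps is.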